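Benzoyl to 4-chlorophenyl at the limit of the assay

The compounds below may be only part of what the source reports. "The series", "measured", "known", "first", "only" and "open" are said of these compounds alone.

In a functional assay on Raji cells (Homo sapiens) for cytotoxicity, with a stated time of 72 h (a lower number here means that less compound is needed, a higher number that more compound is needed for the effect), compound 1 `C=C[C@@](C)(/C=C/c1ccc(O)cc1)CC/C=C/C(=O)OCC` reads > 26000 nM as a limit of the assay. Compound 2 `C=C[C@@](C)(/C=C/c1ccc(O)cc1)CC/C=C(C)/C=C/C(=O)OCC` reads > 26000 nM as a limit as well. Compound 3 `C=C[C@@](C)(/C=C/c1ccc(O)c(/C=C/C(=O)c2ccccc2)c1)CCC=C(C)C` also reads > 26000 nM as a limit, so it has no number of its own. Compound 4 `C=C[C@@](C)(/C=C/c1ccc(O)c(/C=C/c2ccc(Cl)cc2)c1)CCC=C(C)C` differs from it by 4-chlorophenyl in place of benzoyl on a double-bonded chain carbon bound to a double-bonded chain carbon in one place, with 4-chlorophenyl in place of benzoyl on a double-bonded chain carbon bound to a double-bonded chain carbon. Going by the values given here, no measured step exists to guide the forecast, only the limit of > 26000 nM in this assay, at which 3 of the 3 values shown sit, as the common result. The estimated change is an at least 1.3-fold lower number from compound 3 to compound 4 (0.11 log units; that floor lies within the scatter) and is expected to be a small fall in this assay if any. For compound 4 the estimated value is 20000 nM with 7000 nM to 35000 nM as the expected range.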

Compound 4, half-maximal effective concentration: > 26000 nM
Compound 4 gave a limit, no number (the forecaster's own chance of this, stated with the estimate: 55%); at least 1.3-fold (0.11 log units) between middle value and limit.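

In this assay compound 4 reads > 26000 nM, a limit and not a number, so no step can be read between compound 3 and compound 4. The compounds shown leave open how far any of them lies from that limit: the limit of > 26000 nM in this assay, at which 4 of the 4 values shown sit.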